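Working notes: carboxymethyl to propanoyl on the shared core

The source may report more compounds than this note shows. Statements on the series, on what has been measured and on what is new or still open speak of the compounds shown alone.

Measured in a functional assay on MCF7 cells (Homo sapiens) for inhibition, read by radiometric assay and XTT assay; a higher number here means a weaker inhibitor, a lower number a stronger inhibitor:
- compound 1 `CCCCCCCC[C@@]1(C)SC(=O)C=C1OCC(=O)OCC`: 35.3 ug/mL
- compound 2 `CCCCCC[C@@]1(C)SC(=O)C=C1OCCCCCl`: 20.8 ug/mL
- compound 3 `CCCCCCCC[C@@]1(C)SC(=O)C=C1OCC(=O)O`: 50.3 ug/mL

Compound 3, at 50.3 ug/mL, lies within the scatter of compound 1, at 35.3 ug/mL. Compound 2, at 20.8 ug/mL, gives a lower number than compound 3, and that gap lies beyond the scatter.

The next compound is compound 4 `CCCCCCCC[C@@]1(C)SC(=O)C=C1OC(=O)CC`, with propanoyl in place of carboxymethyl on an oxygen on an unsaturated carbon, or carboxymethoxy to propanoyloxy: propanoyl in place of carboxymethyl on an oxygen on an unsaturated carbon.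

Among the measured compounds shown here, only one measured step changes a single place. It is a 1.4-fold higher number from compound 1 to compound 3 (0.15 log units; within the scatter), with hydrogen in place of ethyl in the carboxymethyl group. For the measured compounds named here, that step stays within the scatter, but it is only a weak guide, since no measured compound carries propanoyl. Going by the values given here, compound 2 differs from the others in more than one place, so it gives no clean step, although its value shows the span of numbers seen so far in this assay.

No change beyond the scatter is therefore expected, and the expected step is a 1.4-fold lower number from compound 3 to compound 4 (0.16 log units; within the scatter). For compound 4 the estimated value is 35 ug/mL, with an expected range of 15 ug/mL to 75 ug/mL.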

Compound 4, half-maximal inhibitory concentration: 26.8 ug/mL
Compound 4: middle estimate off by 1.3-fold (0.12 log units), on the high side; the range from low to high includes it.
By their numbers in this assay, from the lowest: compounds 2, 4, 1 and 3 (each within the scatter of the next, the first and the last beyond it).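

In this assay, the oxygen on an unsaturated carbon now carries a group attached through its carbonyl, and the number stays within the scatter: a 1.9-fold lower number from compound 3 to compound 4 (0.27 log units; within the scatter), and, with propanoyl in place of (ethoxycarbonyl)methyl, a 1.3-fold lower number from compound 1 to compound 4 (0.12 log units; within the scatter). Among the compounds shown here, earlier, the only single-place step altered the far end of the carboxymethyl group; these steps replace the whole group on this oxygen, so tolerance at this position now covers more than that one end. Carboxymethyl counts one hydrogen-bond donor and propanoyl none, yet this difference comes with no step beyond the scatter, and no measurement at hand gives a reason for these steps.

The compounds shown leave open whether an amine, a benzoyl group or a much longer acyl chain on this oxygen would move the number beyond the scatter in this assay. For the compounds shown here, they also leave open how the alkyl chain on the shared core acts with propanoyl in place, since compound 2 differs from compound 4 in more than one place and gives no clean step.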